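The compounds below may be only part of what the source reports. "The series", "measured", "known", "first", "only" and "open" are said of these compounds alone.

Of the compounds shown here, two of a shared core have been measured in an assay on HEK293 cells for activation of Kir3.1/Kir3.2 (Homo sapiens), read by thallium flux; on this read-out lower numbers stand for smaller maximal responses and higher numbers for larger maximal responses. Compound 1 `Cc1cc(NC(=O)Cn2nnc(-c3ccccc3)n2)n(C2CCOCC2)n1` carries a phenyl group and in this assay gives 115%. Compound 2 `Cc1cc(NC(=O)Cn2nnc(-c3cc(Cl)cc(Cl)c3)n2)n(C2CCCCC2)n1` carries a 3,5-dichlorophenyl group instead and a different ring on the core, and in this assay compound 2 gives 82%. Of the two numbers, compound 2 stands lowest, and compound 1 lies above it by a gap beyond the usual scatter. Since the two differ in more than one place, no single step can be read from them.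

Compound 3 `COc1ccc(-c2nnn(CC(=O)Nc3cc(C)nn3C3CCCCC3)n2)cc1` is not yet measured. It differs from compound 2 in one place: 4-methoxyphenyl in place of 3,5-dichlorophenyl on an aromatic carbon. Among the measured compounds shown here, with only two measured compounds and no single-place step available, the expectation rests on little. Compound 3 is expected to give 95% in this assay, with a range from 70% to 120%. That estimate means a step of a number 13 percentage points higher from compound 2 to compound 3 (beyond the scatter), expected small and upward, close to the scatter.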

Compound 3, largest response reached (Emax), in percent of the reference or control that the assay uses: 90%
The estimate for compound 3 lay 5 percentage points above the measured number, and the stated range covers the measured number.
By their numbers in this assay, from the lowest: compounds 2 and 3 (each within the scatter of the next); then compound 1.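

In this assay, among the compounds shown here, putting 4-methoxyphenyl in place of 3,5-dichlorophenyl on the aromatic carbon between two ring nitrogen atoms gives a number 8 percentage points higher from compound 2 to compound 3 (within the scatter), the first single-place step in this set. Two chlorine atoms leave and one oxygen atom enters, adding one hydrogen-bond acceptor, yet the maximal responses of the two compounds cannot be told apart, so this position holds either group with no readable difference in this read-out. No measurement of any property of these groups is available to bear on this result.

Going by these compounds, compound 1 differs from each of the other two compounds in more than one place, so its steps to them cannot be read, and the separate contributions of the phenyl group and the ring on the core remain open. Also open, on these data alone, is how the response would look with an amine or a carboxylic acid on this aromatic ring.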